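Swapping the Benzothiazole Group in a Cytotoxicity Series

The source may hold more compounds than are shown below. What is called first, only, known or untested is meant among the compounds shown, and "the series" means these compounds.

Compound 1, `COc1ccc(-c2cc(C(=O)Nc3nc4ccc(F)cc4s3)nc3cc(-c4ccccc4)nn23)cc1`: 31400 nM
Compound 2, `COc1ccc2nc(NC(=O)c3cc(-c4ccc(OC)c(OC)c4)n4nc(-c5ccccc5)cc4n3)sc2c1`: 14000 nM
Compound 3, `COc1ccc2nc(NC(=O)c3cc(-c4cc(OC)c(OC)c(OC)c4)n4nc(-c5ccccc5)cc4n3)sc2c1`: 3980 nM

Of the compounds shown here, three built on a shared core have been tested in a functional assay on DU-145 cells (Homo sapiens) for cytotoxicity, read by MTT assay, with a stated time of 48 h; on this read-out lower numbers stand for stronger inhibition and higher numbers for weaker inhibition. Compound 3 stands lowest of the three numbers, with 3980 nM. For the measured compounds named here, the only comparison that rests on a single change is a 3.5-fold lower number from compound 2 to compound 3 (0.55 log units; beyond the scatter), brought about by a methoxy in place of hydrogen on an aromatic carbon. Compound 1 differs from compound 3 in more than one place, so its higher number cannot be tied to any one change.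

Compound 4, `COc1cc(-c2cc(C(=O)Nc3nc4cc(C)c(C)cc4s3)nc3cc(-c4ccccc4)nn23)cc(OC)c1OC`, carries the change (5,6-dimethyl-1,3-benzothiazol-2-yl in place of 6-methoxy-1,3-benzothiazol-2-yl on an amide-type nitrogen). Going by the values given here, no measured pair differs only at this group, so there is no direct guide to the direction or size of its effect. In the absence of such evidence, the step is expected to stay within the usual scatter, with the same core and the trimethoxyphenyl of compound 3 retained. Compound 4 is therefore estimated to give about 3500 nM, with a likely range from 900 nM to 14000 nM. That estimate means an expected 1.1-fold lower number from compound 3 to compound 4 (0.06 log units; within the scatter).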

Compound 4, half-maximal inhibitory concentration: 3710 nM
Estimate against measurement, compound 4: 1.1-fold (0.03 log units) below; low and high end bracket the measured number.
By their numbers in this assay, from the lowest: compounds 4 and 3 (each within the scatter of the next); then compound 2; then compound 1.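

In this assay, putting 5,6-dimethyl-1,3-benzothiazol-2-yl in place of 6-methoxy-1,3-benzothiazol-2-yl on the amide-type nitrogen gives a 1.1-fold lower number from compound 3 to compound 4 (0.03 log units; within the scatter), so the two compounds cannot be told apart on this read-out. For the compounds shown here, this is the first comparison in which only this group changes, and it shows that, with the rest of compound 3 kept, the oxygen of the methoxy group is not needed to hold the number at this level. Nothing available explains why the two groups give such similar results.

Going by these compounds, it remains open whether an amine or a carboxylic acid on the benzothiazole would leave the number just as undisturbed. On these data alone, it is equally open whether the same swap would behave this way with the aromatic group carried by compound 2.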